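This account rests on a few compounds, and the source may have more. Where it says the series, first, only, none or still open, it means among the compounds named here.

In an ADME assay on BJ cells (Homo sapiens) for cytotoxicity, read by MTT assay, with a stated time of 72 h (on this read-out higher numbers stand for lower toxicity in this test and lower numbers for higher toxicity in this test), compound 1 `OC[C@H]1O[C@@H](n2cc(F)c3c(-c4ccccc4)ncnc32)[C@H](O)[C@@H]1O` reports only a limit, > 50000 nM. Compound 2 `OC[C@H]1O[C@@H](n2cc(F)c3c(-c4ccoc4)ncnc32)[C@H](O)[C@@H]1O` gives 350 nM and compound 3 `OC[C@H]1O[C@@H](n2cc(F)c3c(-c4ccc[nH]4)ncnc32)[C@H](O)[C@@H]1O` gives 2990 nM, which leaves compound 2 with the lowest number of the three. Compound 4 `OC[C@H]1O[C@@H](n2cc(Cl)c3c(-c4ccoc4)ncnc32)[C@H](O)[C@@H]1O` differs from compound 2 in one place, chloro in place of fluoro on an aromatic carbon. The measured steps all swap a different group: an at least 140-fold lower number from compound 1 to compound 2 (2.15 log units; beyond the scatter), an at least 16-fold lower number from compound 1 to compound 3 (1.22 log units; beyond the scatter) and an 8.5-fold higher number from compound 2 to compound 3 (0.93 log units; beyond the scatter). They were modest to large, showing that this assay responds strongly to that group, but none tests the fluoro site. With no measured guide for this site, no change beyond the scatter is expected, although a surprise is possible. The expected step is a 1.1-fold higher number from compound 2 to compound 4 (0.06 log units; within the scatter). Compound 4 is estimated at 400 nM, with an expected range of 120 nM to 1500 nM.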

Compound 4, half-maximal cytotoxic concentration: 21600 nM
For compound 4 the middle estimate is 54-fold (1.73 log units) below the measured one, and the stated range ends below it.
By their numbers in this assay, from the lowest: compound 2; then compound 3; then compound 4. At a limit, above all of these: compound 1.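

In this assay the fluoro site proves sensitive: chloro in place of fluoro gives a 62-fold higher number from compound 2 to compound 4 (1.79 log units; beyond the scatter), although only one heavy atom is exchanged for another and no ring, hydrogen-bond donor, hydrogen-bond acceptor or net charge changes. A step this large shows that this position on the five-membered aromatic ring also shapes the read-out, not only the group swapped earlier. Compound 4 gives a true number rather than a limit, so this step has a definite size, while the ceiling remains in view: the limit of > 50000 nM in this assay, at which 1 of the 4 values shown sits.

Chloro is seen here only alongside furan-3-yl, so the same step with phenyl or 1H-pyrrol-2-yl remains open. Bromo, methyl or an amine at this site could show how the read-out continues beyond these two halogens.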